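A few compounds are considered here, and "the series" means these few. Any claim that something is new, unique, unknown or untested is made for them only; others in the source may bear on it.

The three compounds measured so far in a functional assay on K562 cells (Homo sapiens) for inhibition, read by MTT assay, with a stated time of 72 h; a higher number here means a weaker inhibitor, a lower number a stronger inhibitor:

Compound 1, `O=C(O)/C=C/C(=O)c1ccccc1`, gives 30200 nM.
Compound 2, `Cc1ccc(C)c(C(=O)/C=C/C(=O)O)c1`, gives 5900 nM.
Compound 3, `CC(C)c1ccc(C(C)C)c(C(=O)/C=C/C(=O)O)c1`, gives 3280 nM.

Compound 1 has the highest number of the three and is therefore the weakest inhibitor here; compound 2 lies nearest to it and compound 3 furthest, and both gaps are beyond the usual scatter. Compound 4, `O=C(O)/C=C/C(=O)c1ccc(F)cc1`, has not been measured. It differs from compound 1 in one place: fluoro in place of hydrogen on an aromatic carbon. For the measured compounds named here, no measured pair shows this change on its own, so its effect in this assay cannot be read off directly. Compounds 2 and 3 carry other groups on the same ring and both give lower numbers than compound 1, but those are different changes. The expected step is small, toward a lower number or none beyond the scatter: a 1.5-fold lower number from compound 1 to compound 4 (0.18 log units; within the scatter). For compound 4 the estimate is 20000 nM, within a range of 7000 nM to 50000 nM.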

Compound 4, half-maximal inhibitory concentration: 16900 nM
Compound 4: middle estimate off by 1.2-fold (0.07 log units), on the high side; the measured number falls inside the stated range.
By their numbers in this assay, from the lowest: compounds 3 and 2 (each within the scatter of the next); then compounds 4 and 1 (each within the scatter of the next).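

Fluoro in place of hydrogen on an aromatic carbon, para to a group of 7 heavy atoms, can now be read on its own: in this assay it gives a 1.8-fold lower number from compound 1 to compound 4 (0.25 log units; within the scatter) and so does not clearly separate the two compounds. At this place, then, a single fluoro makes no change that these numbers can distinguish from repeat-to-repeat variation. Nothing given here bears on the reason for this result. Still open, going by these compounds, is whether another group at this place, such as an amine or a methoxy group, would give a step beyond the scatter.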